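The source may report more compounds than this note shows. Statements on the series, on what has been measured and on what is new or still open speak of the compounds shown alone.

Compound 1 `COc1ccc(C(=O)C2=C(O)C(=O)N(c3ccc(-c4ccon4)cc3)C2c2ccccc2OC)cc1` gives 34700 nM in a physicochemical assay for solubility, in phosphate buffer, at pH 6.8; on this read-out lower numbers stand for lower solubility and higher numbers for higher solubility. Compound 2 `COc1ccc(C(=O)C2=C(O)C(=O)N(c3ccc(-c4ccon4)cc3)C2c2ccccc2OCCO)cc1` reaches only a limit of this assay, > 50000 nM. Compound 3 `CC(C)(C)C(=O)C1=C(O)C(=O)N(c2ccc(-c3ccon3)cc2)C1c1ccccc1OCCO` likewise reaches only a limit of this assay, > 50000 nM. The step of an at least 1.4-fold higher number from compound 1 to compound 2 (0.15 log units; that floor lies within the scatter) is a floor that sits within the scatter, and the step that the two limits leave unreadable from compound 2 to compound 3 cannot be sized. Compound 3 therefore stands at the limit of > 50000 nM in this assay, at which 2 of the 3 values shown sit, and no number is known for it. Compound 4 `Cc1noc(-c2ccc(N3C(=O)C(O)=C(C(=O)C(C)(C)C)C3c3ccccc3OCCO)cc2)n1` differs from compound 3 by 3-methyl-1,2,4-oxadiazol-5-yl in place of 1,2-oxazol-3-yl on an aromatic carbon. For the measured compounds named here, no measured step touches this ring, so none gives a size to lean on. Compound 4 is expected to remain at the limit, with an expected step that the limit leaves unreadable from compound 3 to compound 4 that is not readable beyond the scatter, and its estimated solubility is 60000 nM, within 25000 nM to 150000 nM.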

Compound 4, solubility: > 50000 nM
Compound 4: a limit, no number; the forecaster's own chance of this, stated with the estimate: 70%; the middle value lies beyond the limit too.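

In this assay, for the compounds shown here, compound 4 gives > 50000 nM, a limit and not a number, as is the result for compound 3, so no step between compound 3 and compound 4 can be read. On these data alone, the actual solubility of either compound remains open.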